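The source may report more compounds than this note shows. Statements on the series, on what has been measured and on what is new or still open speak of the compounds shown alone.

Measured compounds:
compound 1, `CCNCC(=O)Nc1cc(OC)ccc1C(=O)c1cc(OC)c(OC)c(OC)c1`: 2100 nM
compound 2, `COc1ccc(C(=O)c2cc(OC)c(OC)c(OC)c2)c(NC(=O)CN(C)C)c1`: 470 nM
compound 3, `C=C(c1ccc(OC)cc1NC(=O)CNCC)c1ccc(OC)c2c1OC(C)(C)C=C2`: 1090 nM

All three were tested in a functional assay on HeLa cells (Homo sapiens) for antiproliferative activity, read by MTT assay, with a stated time of 48 h; on this read-out higher numbers stand for weaker inhibition and lower numbers for stronger inhibition. Compound 1 and compound 2 share one core and differ only in the amide side chain: the change is dimethylamino in place of ethylamino on a saturated chain carbon bound to a carbonyl carbon. On this change the number moves by a 4.5-fold lower number from compound 1 to compound 2 (0.65 log units; beyond the scatter). Compound 3 is built on a different core, and the difference between the two cores is not broken down here. In this assay compound 3 gives 1090 nM, which stands within the scatter of compound 1 and lies beyond the scatter above compound 2.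

Compound 4, `C=C(c1ccc(OC)cc1NC(=O)CN(C)C)c1ccc(OC)c2c1OC(C)(C)C=C2`, has not yet been measured. It stands to compound 3 as compound 2 stands to compound 1: the change is dimethylamino in place of ethylamino on a saturated chain carbon bound to a carbonyl carbon, the same change made on the other core. On the first core the step was a 4.5-fold lower number from compound 1 to compound 2 (0.65 log units; beyond the scatter). Within the data shown here, since the same exchange at the same place gave that step, the expected step from compound 3 to compound 4 is a 3.6-fold lower number from compound 3 to compound 4 (0.56 log units; beyond the scatter), kept a little smaller than the one seen because only a single pair, compound 1 and compound 2, supports it and the cores differ. On that footing compound 4 is expected to give 300 nM in this assay, with a likely range from 120 nM to 800 nM.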

Compound 4, half-maximal inhibitory concentration: 900 nM
Beside the measured number, compound 4's estimate is 3.0-fold (0.48 log units) below it; measured number outside the range, above it.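

In this assay, placing dimethylamino instead of ethylamino on the saturated chain carbon bound to the carbonyl carbon gives a 1.2-fold lower number from compound 3 to compound 4 (0.08 log units; within the scatter), and this step differs from the one seen on the core of compound 1: the same change on two cores in this assay, a 4.5-fold lower number (0.65 log units; beyond the scatter) from compound 1 to compound 2 and a 1.2-fold lower number (0.08 log units; within the scatter) from compound 3 to compound 4, 3.7-fold (0.57 log units) apart, beyond the scatter of two such steps The size of the step on the core of compound 1 therefore did not carry over to the core of compound 3, so for these two pairs the outcome of the exchange depends on the core that bears it. Among these compounds, this does not show which feature of the two cores separates the steps, and with only one pair on each core it gives no general rule for the series.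

The compounds shown leave open how the two cores would respond to other groups at this place, such as a primary amine, diethylamino, morpholine or a longer chain, and so whether the difference is peculiar to the exchange of ethylamino for dimethylamino. They also leave open which of the structural differences between the two cores matters, since no compound shown stands between them with only one of those differences made.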